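Swapping the Nitro for a Nitrile on the Benzyl Ether

This account rests on a few compounds, and the source may have more. Where it says the series, first, only, none or still open, it means among the compounds named here.

Compound 1, `COc1cc(OC)c(-c2coc3cc(OCc4ccccc4)ccc3c2=O)cc1OC`: 2330 nM
Compound 2, `COc1cc(OC)c(-c2coc3cc(OCc4ccc([N+](=O)[O-])cc4)ccc3c2=O)cc1OC`: > 10000 nM

In a functional assay on B16 cells (Mus musculus) for antiproliferative activity, read by MTT assay, with a stated time of 24 h (on this read-out lower numbers stand for stronger inhibition and higher numbers for weaker inhibition), compound 2 gives > 10000 nM, which is a limit of the assay rather than a number (the limit of > 10000 nM in this assay, at which 1 of the 2 values shown sits). Compound 1 gives 2330 nM. Among the measured compounds shown here, the one measured step, an at least 4.2-fold higher number from compound 1 to compound 2 (0.63 log units; beyond the scatter), shows that placing a nitro group on the benzyl ring weakens the activity. Compound 3, `COc1cc(OC)c(-c2coc3cc(OCc4ccccc4C#N)ccc3c2=O)cc1OC`, differs from compound 2 by 2-cyanophenyl in place of 4-nitrophenyl on a saturated chain carbon bound to an oxygen on an aromatic ring: the group with 1 double bond outside aromatic rings leaves and a group with 1 triple bond outside aromatic rings enters. For the measured compounds named here, no measured pair shows what a 2-cyanophenyl does here, and because compound 2 sits only at a limit, the size of the step cannot be pinned down. The nitro group that weakened compound 1 is removed, so the number for compound 3 is expected to be 5000 nM, between 1500 nM and 20000 nM, which means an estimated step of an at least 2.0-fold lower number from compound 2 to compound 3 (0.30 log units; that floor lies within the scatter).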

Compound 3, half-maximal inhibitory concentration: 2140 nM
Estimate against measurement, compound 3: 2.3-fold (0.37 log units) above, and the stated range covers the measured number.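

In this assay the step of a 1.1-fold lower number from compound 1 to compound 3 (0.04 log units; within the scatter) shows that a group added to the benzyl ring need not cost activity, as the nitro group did in compound 2. The step of an at least 4.6-fold lower number from compound 2 to compound 3 (0.66 log units; beyond the scatter) places the 2-cyanobenzyl group clearly ahead of the 4-nitrobenzyl group on this ether oxygen. The full size of that step cannot be read, because compound 2 stands at a limit: the limit of > 10000 nM in this assay, at which 1 of the 3 values shown sits.

Compound 2 and compound 3 differ both in the group on the ring and in where it sits, so the compounds shown cannot separate the effect of the group from the effect of its place. Also open, on these data alone, is how a 4-cyanobenzyl or 2-nitrobenzyl group would compare, and what an amine or a carboxylic acid on the benzyl ring would do.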